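Adding a Methoxy Group to the Benzoyl Ester

A few compounds are considered here, and "the series" means these few. Any claim that something is new, unique, unknown or untested is made for them only; others in the source may bear on it.

Measured in a functional assay on K562 cells (Homo sapiens) for cytotoxicity, read by MTT assay, with a stated time of 72 h; on this read-out higher numbers stand for weaker inhibition and lower numbers for stronger inhibition:
- Compound 1 `C=C1C(=O)[C@@]23C(=O)OC[C@]4(C(=O)CCC(C)(C)[C@H]4C=O)[C@@H]2CC[C@@H]1[C@H]3O` gives 2180 nM
- Compound 2 `C=C1C(=O)[C@@]23C(=O)OC[C@]4(C(=O)CCC(C)(C)[C@H]4C=O)[C@@H]2CC[C@@H]1[C@H]3OC(=O)CC` gives 1310 nM
- Compound 3 `C=C1C(=O)[C@@]23C(=O)OC[C@]4(C(=O)CCC(C)(C)[C@H]4C=O)[C@@H]2CC[C@@H]1[C@H]3OC(=O)c1ccccc1` gives 1480 nM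

Compound 3 holds no distinct rank among these values, since both of its steps lie within the scatter (a 1.1-fold higher number from compound 2 to compound 3 (0.05 log units; within the scatter)) and (a 1.5-fold lower number from compound 1 to compound 3 (0.17 log units; within the scatter)). Compound 4 `C=C1C(=O)[C@@]23C(=O)OC[C@]4(C(=O)CCC(C)(C)[C@H]4C=O)[C@@H]2CC[C@@H]1[C@H]3OC(=O)c1ccc(OC)cc1` differs from it by one change, methoxy in place of hydrogen on an aromatic carbon, para to a large group (methoxy in place of hydrogen on an aromatic carbon). For the measured compounds named here, no measured step covers a substituent on this aromatic ring. The closest evidence is the phenyl for ethyl swap above, and the propanoyl step (a 1.7-fold lower number from compound 1 to compound 2 (0.22 log units; within the scatter)) also stayed within the scatter. The expected step (a 1.1-fold lower number from compound 3 to compound 4 (0.02 log units; within the scatter)) therefore goes in no clear direction and stays within the scatter. Compound 4 is estimated at 1400 nM (range 800 nM to 2400 nM).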

Compound 4, half-maximal inhibitory concentration: 1650 nM
The estimate for compound 4 lay 1.2-fold (0.07 log units) below the measured number; low and high end bracket the measured number.
By their numbers in this assay, from the lowest: compounds 2, 3, 4 and 1 (each within the scatter of the next).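

In this assay, for the compounds shown here, methoxy is the first substituent seen on the aromatic ring of the ester, and it leaves the number within the scatter (a 1.1-fold higher number from compound 3 to compound 4 (0.05 log units; within the scatter)). The same holds against the propanoyl ester (a 1.3-fold higher number from compound 2 to compound 4 (0.10 log units; within the scatter)) and the free alcohol (a 1.3-fold lower number from compound 1 to compound 4 (0.12 log units; within the scatter)), so compound 4 does not separate from any of the three earlier compounds. No available evidence bears on this flat result. From the compounds shown here alone, whether an amine or a carboxylic acid on this aromatic ring, or a longer chain in place of the ethyl of compound 2, would move the number beyond the scatter remains open.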